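Tolerated Concentrations in Akata Cells and a Fourth Compound

This account rests on a few compounds, and the source may have more. Where it says the series, first, only, none or still open, it means among the compounds named here.

Compounds 1, 2 and 3 have been tested in an ADME assay on Akata cells (Homo sapiens) for cytotoxicity, with a stated time of 7 days (a lower number here means that less compound is tolerated, a higher number that more compound is tolerated), and each result is a limit of the assay rather than a number:

Compound 1, `CCCCCCCCOc1nc(N)nc2c1ncn2/C=C1/CC1(CO)CO`: > 20000 nM
Compound 2, `Nc1nc(NC2CCCCC2)c2ncn(/C=C3/CC3(CO)CO)c2n1`: > 24000 nM
Compound 3, `CSc1nc(N)nc2c1ncn2/C=C1/CC1(CO)CO`: > 20000 nM

Compound 3 stands at the limit of > 20000 nM in this assay, at which 2 of the 3 values shown sit. The same limit is shared by compound 1, while compound 2 stands at the limit of > 24000 nM in this assay, at which 1 of the 3 values shown sits. None of the three steps can be read as a size: a step that the two limits leave unreadable from compound 1 to compound 3, a step that the two limits leave unreadable from compound 2 to compound 3 and a step that the two limits leave unreadable from compound 1 to compound 2 all fall between two limits. Compound 4, `CC(C)Sc1nc(N)nc2c1ncn2/C=C1/CC1(CO)CO`, differs from compound 3 in that (isopropyl in place of methyl on a sulfur). For the measured compounds named here, no measured step therefore bears on this change with a readable size, so no direction beyond the scatter can be drawn from the three measured compounds. Compound 4 is expected to be tolerated in the same way, most likely reported again as a limit. The estimate for compound 4 is 30000 nM, with a range from 15000 nM to 100000 nM, and the expected step is a step that the limit leaves unreadable from compound 3 to compound 4.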

Compound 4, half-maximal cytotoxic concentration: > 20000 nM
Compound 4 gave a limit, no number; the forecaster's own chance of this, stated with the estimate: 80%; the middle value does not contradict the limit.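

In this assay, for the compounds shown here, compound 4 gives only a limit, as do compound 1, compound 2 and compound 3, so no step from any of them to compound 4 can be read as a size. The compounds shown leave open the concentration at which any of the four becomes cytotoxic.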